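Methoxy to dimethylamino swap, repeated on a hydroxylated core

A few compounds are considered here, and "the series" means these few. Any claim that something is new, unique, unknown or untested is made for them only; others in the source may bear on it.

Of the compounds shown here, three have been measured in a functional assay on PC-3 cells (Homo sapiens) for inhibition, read by sulforhodamine B assay; on this read-out higher numbers stand for weaker inhibition of growth and lower numbers for stronger inhibition of growth. Compound 1 `COc1ccc(-c2ccc(-c3ccc(-c4nc5ccccc5[nH]4)cc3)cc2)cc1` gives 100000 nM in this assay. Compound 2 `CN(C)c1ccc(-c2ccc(-c3ccc(-c4nc5ccccc5[nH]4)cc3)cc2)cc1` carries dimethylamino in place of methoxy on an aromatic carbon and gives 100000 nM in this assay; the step is no change at the digits printed from compound 1 to compound 2 (within the scatter). Compound 3 `COc1ccc(-c2ccc(-c3ccc(-c4nc5c(O)cccc5[nH]4)cc3)cc2)cc1` differs from compound 1 by hydroxy in place of hydrogen on an aromatic carbon; in this assay compound 3 gives 6610 nM, and the step is a 15-fold lower number from compound 1 to compound 3 (1.18 log units; beyond the scatter). Compound 3 therefore stands lowest of the three, with compound 1 and compound 2 both beyond the scatter above it.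

Compound 4 `CN(C)c1ccc(-c2ccc(-c3ccc(-c4nc5c(O)cccc5[nH]4)cc3)cc2)cc1` has not been measured. It differs from compound 3 by dimethylamino in place of methoxy on an aromatic carbon. This is the same change as the one between compound 1 and compound 2, made on a core that differs by hydroxy in place of hydrogen on an aromatic carbon; among the compounds shown it occurs twice, once measured and once still open. Among the measured compounds shown here, the only precedent for the change, no change at the digits printed from compound 1 to compound 2 (within the scatter), is flat, so the step from compound 3 to compound 4 is expected to be a 1.1-fold higher number from compound 3 to compound 4 (0.02 log units; within the scatter), resting on that single precedent alone. With one example on a different core, the expectation is thin, and a wider range is kept around it. Compound 4 is expected to give about 7000 nM in this assay, estimated to fall between 2500 nM and 25000 nM.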

Compound 4, concentration for 50% growth inhibition: 8420 nM
The estimate for compound 4 lay 1.2-fold (0.08 log units) below the measured number; measured number inside the range.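

In this assay, dimethylamino in place of methoxy on the hydroxylated core gives a 1.3-fold higher number from compound 3 to compound 4 (0.11 log units; within the scatter), so the change that was flat on the core of compound 1 is also flat here, and the two cores agree: the same change on two cores in this assay, no change at the digits printed (within the scatter) from compound 1 to compound 2 and a 1.3-fold higher number (0.11 log units; within the scatter) from compound 3 to compound 4, 1.3-fold (0.11 log units) apart, within the scatter of two such steps. The hydroxy change likewise holds when dimethylamino replaces methoxy, with a 12-fold lower number from compound 2 to compound 4 (1.07 log units; beyond the scatter), which agrees with the step seen in the methoxy pair: the same change on two cores in this assay, a 15-fold lower number (1.18 log units; beyond the scatter) from compound 1 to compound 3 and a 12-fold lower number (1.07 log units; beyond the scatter) from compound 2 to compound 4, 1.3-fold (0.11 log units) apart, within the scatter of two such steps. Across these four compounds, the two changes therefore behave independently, with the hydroxy group accounting for the large steps and the swap between methoxy and dimethylamino for none beyond the scatter, but this rests on two cores and two groups at a single place, and it does not show that the swap would stay flat on any other core or that the pattern extends to other groups.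

Still open, going by these compounds, is whether a group other than these two at the same place, such as a carboxylic acid or a longer alkoxy chain, would also leave the number unchanged. On these data alone, it is equally open whether the gain tied to the hydroxy group survives when that hydroxy is replaced by an amine or a methoxy group.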